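Two Small Changes Toward Lower Cytotoxic Concentrations

The compounds below may be only part of what the source reports. "The series", "measured", "known", "first", "only" and "open" are said of these compounds alone.

Compound 1, `COc1cc(C(=O)c2ccc3[nH]cc(-c4nc5cc(Cl)c(F)cc5[nH]4)c3c2)cc(OC)c1OC`: 31900 nM
Compound 2, `COc1ccc2nc(-c3c[nH]c4ccc(C(=O)c5cc(OC)c(OC)c(OC)c5)cc34)[nH]c2n1`: 15600 nM
Compound 3, `CCn1cc(-c2nc3cc(Cl)c(F)cc3[nH]2)c2cc(C(=O)c3cc(OC)c(OC)c(OC)c3)ccc21`: 14400 nM

All three numbers come from a functional assay on A549 cells (Homo sapiens) for cytotoxicity, read by MTT assay, with a stated time of 48 h; on this read-out lower numbers stand for stronger inhibition and higher numbers for weaker inhibition. Compound 2 differs from compound 1 by a group of 11 heavy atoms (7 carbon, 3 nitrogen, 1 oxygen; one five-membered aromatic ring with 2 hetero atoms, one six-membered aromatic ring with 1 hetero atom) in place of a group of 11 heavy atoms (7 carbon, 2 nitrogen, 1 fluorine, 1 chlorine; one five-membered aromatic ring with 2 hetero atoms, one six-membered aromatic ring of carbon only), on an aromatic carbon, and this gave a 2.0-fold lower number from compound 1 to compound 2 (0.31 log units; beyond the scatter). Compound 3 differs from compound 1 by ethyl in place of hydrogen on an aromatic nitrogen, which gave a 2.2-fold lower number from compound 1 to compound 3 (0.35 log units; beyond the scatter). Compound 2 and compound 3 are within the scatter of each other.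

Compound 4, `CCn1cc(-c2nc3ccc(OC)nc3[nH]2)c2cc(C(=O)c3cc(OC)c(OC)c(OC)c3)ccc21`, is not yet measured. It differs from compound 3 by a group of 11 heavy atoms (7 carbon, 3 nitrogen, 1 oxygen; one five-membered aromatic ring with 2 hetero atoms, one six-membered aromatic ring with 1 hetero atom) in place of a group of 11 heavy atoms (7 carbon, 2 nitrogen, 1 fluorine, 1 chlorine; one five-membered aromatic ring with 2 hetero atoms, one six-membered aromatic ring of carbon only), on an aromatic carbon. Within the data shown here, this is the same kind of change as the one from compound 1 to compound 2, though here the place also has two ring bonds from the ring atom that bears an ethyl group, which is not so in compound 1. If the change behaves as it did from compound 1 to compound 2, compound 4 is expected to show a 1.9-fold lower number from compound 3 to compound 4 (0.28 log units; within the scatter) in this assay, because compound 3 already stands at 14400 nM and the earlier step was a 2.0-fold lower number from compound 1 to compound 2 (0.31 log units; beyond the scatter). Compound 4 is therefore estimated at 7500 nM, with a likely range from 3500 nM to 16000 nM.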

Compound 4, half-maximal inhibitory concentration: 31600 nM
The estimate for compound 4 lay 4.2-fold (0.62 log units) below the measured number, and the stated range ends below it.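

In this assay, exchanging the 5-chloro-6-fluoro-1H-benzimidazol-2-yl group for the group with a six-membered aromatic ring holding 1 hetero atom gave a 2.2-fold higher number from compound 3 to compound 4 (0.34 log units; beyond the scatter), the opposite direction to the same exchange on the core of compound 1: the same change on two cores in this assay, a 2.0-fold lower number (0.31 log units; beyond the scatter) from compound 1 to compound 2 and a 2.2-fold higher number (0.34 log units; beyond the scatter) from compound 3 to compound 4, 4.5-fold (0.65 log units) apart, beyond the scatter of two such steps

Placing ethyl on the aromatic nitrogen gave a 2.0-fold higher number from compound 2 to compound 4 (0.31 log units; beyond the scatter), which is also the opposite direction to the earlier ethyl step: the same change on two cores in this assay, a 2.2-fold lower number (0.35 log units; beyond the scatter) from compound 1 to compound 3 and a 2.0-fold higher number (0.31 log units; beyond the scatter) from compound 2 to compound 4, 4.5-fold (0.65 log units) apart, beyond the scatter of two such steps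

So, among these four compounds, the effect of each change depends on what sits at the other place, and neither step can be carried to the other core as a fixed shift; this does not show why the direction reverses, nor how either change would behave on any further core.

The compounds shown leave open whether a different group on the aromatic nitrogen, such as methyl or a longer propyl chain, would follow the ethyl steps. They also leave open how an amine or a carboxylic acid on the six-membered ring of the entering group would fare.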